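Sulfonamide series: tolerance in cell culture, approaching compound 4

The source may report more compounds than this note shows. Statements on the series, on what has been measured and on what is new or still open speak of the compounds shown alone.

Measured so far:
Compound 1, `O=S(=O)(Nc1ccc2oc(-c3ccccc3)nc2c1)c1ccc(Cl)c(Cl)c1`, gives 71000 nM in an ADME assay on HEK293 cells (Homo sapiens) for cytotoxicity, read by resazurin assay, with a stated time of 48 h; a higher number here means that more compound is tolerated, a lower number that less compound is tolerated.
Compound 2, `Cc1ccccc1S(=O)(=O)Nc1ccc2oc(-c3ccccc3)nc2c1`, gives 57000 nM in this assay.
Compound 3, `O=S(=O)(Nc1ccc2oc(-c3ccccc3)nc2c1)c1ccccc1Cl`, gives 73000 nM in this assay.

Compound 1 stands second highest of the three numbers. Its nearest neighbour is compound 3, the step being a 1.0-fold higher number from compound 1 to compound 3 (0.01 log units; within the scatter); its furthest is compound 2, with a 1.2-fold lower number from compound 1 to compound 2 (0.10 log units; within the scatter). Between the other two the step is a 1.3-fold higher number from compound 2 to compound 3 (0.11 log units; within the scatter). All three steps fall within the scatter, so the three aryl groups on the sulfonyl sulfur give numbers that cannot be told apart in this assay.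

Compound 4, `O=S(=O)(Nc1ccc2oc(-c3ccccc3)nc2c1)c1ccc(Cl)c(C(F)(F)F)c1`, is the next member. Relative to compound 1 the change is trifluoromethyl in place of chloro on an aromatic carbon. Every measured step here alters the aryl on the sulfonyl sulfur, and none of them moved the number beyond the scatter; the change to compound 4 is of the same kind. No step beyond the scatter is therefore expected, and the step is estimated as a 1.0-fold lower number from compound 1 to compound 4 (0.01 log units; within the scatter). Compound 4 is expected to give about 70000 nM in this assay, estimated within 35000 nM to 140000 nM.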

Compound 4, half-maximal cytotoxic concentration: 66000 nM
For compound 4 the middle estimate is 1.1-fold (0.03 log units) above the measured one; measured number inside the range.
By their numbers in this assay, from the lowest: compounds 2, 4, 1 and 3 (each within the scatter of the next).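

In this assay, within the data shown here, the new step changes only one group on the sulfonyl aryl and keeps the other chloro in place, unlike the step from 3,4-dichlorophenyl to 2-methylphenyl or to 2-chlorophenyl. Trifluoromethyl, with 4 heavy atoms, enters for chloro, with 1 heavy atom, ortho to a chloro group and meta to a large group, and the result is a 1.1-fold lower number from compound 1 to compound 4 (0.03 log units; within the scatter), so this larger group at this position leaves the number within the scatter. No data shown give a reason for this result.

As far as these compounds go, what an amine, a carboxylic acid or a longer chain would give in this place stays open. Also open, from the compounds shown here alone, is whether a change to the shared core, rather than to the aryl on the sulfonyl sulfur, would move the number in this assay beyond the scatter.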